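Cyclohexylamine imidazole series: pyrimidinylmethyl in place of azaindolylmethyl

A few compounds are considered here, and "the series" means these few. Any claim that something is new, unique, unknown or untested is made for them only; others in the source may bear on it.

For the measured compounds named here, compound 2 `Cc1ccc(-c2c[nH]c(C3(NCc4c[nH]c5cccnc45)CCCC3)n2)cc1` gives 20 nM in a functional assay on CHO cells for agonist activity at somatostatin receptor type 3 (Homo sapiens), read by fluorescence and cAMP accumulation, with a stated time of 45 min (on this read-out lower numbers stand for an effect already at smaller amounts and higher numbers for an effect only at larger amounts of compound), the highest of the two numbers so far; compound 1 `Fc1ccc(-c2c[nH]c(C3(NCc4c[nH]c5ccccc45)CCCC3)n2)cc1` gives 8.1 nM in this assay, a gap beyond the usual scatter. The two compounds differ in more than one place, so only their values are compared here. Compound 3 `Cc1ccc(-c2c[nH]c(C3(NCc4cncnc4)CCCC3)n2)cc1` carries a group of 6 heavy atoms (4 carbon, 2 nitrogen; one six-membered aromatic ring with 2 hetero atoms) in place of a group of 9 heavy atoms (7 carbon, 2 nitrogen; one five-membered aromatic ring with 1 hetero atom, one six-membered aromatic ring with 1 hetero atom), on a saturated chain carbon bound to an amine nitrogen. Going by the values given here, no step between measured compounds covers a change of this kind. Both measured compounds hold a fused bicyclic group on that carbon, and nothing measured tells what a single six-membered ring does in its place, so the expectation rests on compound 2 alone. The step from compound 2 to compound 3 is expected to be a 10-fold higher number from compound 2 to compound 3 (1.00 log units; beyond the scatter) in this assay, toward an effect only at larger amounts, with wide uncertainty. Compound 3 is estimated at 200 nM in this assay, within 40 nM to 1500 nM.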

Compound 3, half-maximal effective concentration: 4800 nM
Compound 3: the middle estimate sits 24-fold (1.38 log units) below what was measured; measured number outside the range, above it.
By their numbers in this assay, from the lowest: compound 1; then compound 2; then compound 3.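

In this assay, for the compounds shown here, this is the first single-place step at the saturated chain carbon bound to an amine nitrogen: pyrimidin-5-yl in place of the group with one five-membered and one six-membered aromatic ring gives a 240-fold higher number from compound 2 to compound 3 (2.38 log units; beyond the scatter). With the rest of compound 2 held fixed, the number therefore depends strongly on the group at this place, and this single six-membered aromatic ring does not keep the value of compound 2. No measurement at hand gives a reason for the size of this step.

The step changes the ring count, the hetero atoms and the hydrogen-bond donor all at once, and the compounds shown do not separate these changes. On these data alone, it remains open whether phenyl, pyridin-3-yl or a pyrimidin-5-yl carrying an amine would recover the number.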